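This account rests on a few compounds, and the source may have more. Where it says the series, first, only, none or still open, it means among the compounds named here.

In a physicochemical assay for lipophilicity (on this read-out lower numbers stand for lower lipophilicity and higher numbers for higher lipophilicity), compound 1 `COc1cc(-c2noc([C@H](C)NC(=O)c3cc(C(F)(F)F)nn3C)n2)ccn1` gives 3.4 and compound 2 `CNc1cc(-c2noc([C@H](C)NC(=O)c3cc(C(F)(F)F)nn3C)n2)ccn1` gives 3.4, which leaves compound 2 level with compound 1. Compound 3 `COC(C)(C)c1cc(-c2noc([C@H](C)NC(=O)c3cc(C(F)(F)F)nn3C)n2)ccn1` carries 1-methoxy-1-methylethyl in place of methylamino on an aromatic carbon, next to the ring nitrogen and meta to a large group: 1-methoxy-1-methylethyl in place of methylamino on an aromatic carbon. Within the data shown here, only one measured step bears on this change. It exchanges methoxy for methylamino at the same place and shows no change at the digits printed from compound 1 to compound 2 (within the scatter). Among the measured compounds shown here, no measured compound carries 1-methoxy-1-methylethyl, so that step sets no direct size for the new exchange. The entering group is the larger of the two, and a modest rise in this assay is expected, with wide uncertainty. The expected change is a number 0.30 log units higher from compound 2 to compound 3 (within the scatter). The estimated value for compound 3 is 3.7, within an expected range from 3.3 to 4.1.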

Compound 3, distribution coefficient: 3.8
For compound 3 the middle estimate is 0.10 log units below the measured one, within the range that was stated.
By their numbers in this assay, from the lowest: compounds 1 and 2 (each within the scatter of the next); then compound 3.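

In this assay, the aromatic carbon next to the ring nitrogen proves able to move the read-out: 1-methoxy-1-methylethyl in place of methylamino gives a number 0.40 log units higher from compound 2 to compound 3 (beyond the scatter), and the same group in place of methoxy gives a number 0.40 log units higher from compound 1 to compound 3 (beyond the scatter). The earlier exchange of methoxy for methylamino had left compound 1 and compound 2 level, so it gave no sign that a substituent here could shift the number beyond the scatter. No measurement shown accounts for the rise.

The compounds shown leave open whether the step goes with the branched carbon framework of the entering group or with its ether oxygen. A tert-butyl group at the same place would separate those two, and a longer chain would show whether the number keeps climbing as the substituent grows.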